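From 2-fluorophenyl to pyridin-4-yl in a clearance series

The source may report more compounds than this note shows. Statements on the series, on what has been measured and on what is new or still open speak of the compounds shown alone.

Three compounds have a reading so far in an ADME assay (liver) for metabolic stability, with Liver microsome (Homo sapiens) as the target, using microsomes (a higher number here means faster removal of the compound, a lower number slower removal), and no two of them differ in one place only. Compound 1 `c1ccc(CNc2nnc(-c3nc4ccncc4s3)o2)cc1` gives 23 mL.min-1.g-1 in this test, and compound 3 `Fc1ccccc1CNc1nnc(-c2c[nH]c3ncccc23)o1` gives 32 mL.min-1.g-1 with a gap that stays within the scatter. Compound 2 `O=C1Cc2cc(-c3nnc(NCc4ccccc4)o3)ccc2N1` returned < 14 mL.min-1.g-1 as its reading, which is a limit and not a number. Within the data shown here, compound 3 therefore stands level with compound 1, and these two hold the only true numbers available.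

The next step keeps the shared core of compound 3 and changes one group. Compound 4 `c1cnc2[nH]cc(-c3nnc(NCc4ccncc4)o3)c2c1` carries pyridin-4-yl in place of 2-fluorophenyl on a saturated chain carbon bound to a nitrogen on an aromatic ring. The change counts as follows: pyridin-4-yl in place of 2-fluorophenyl on a saturated chain carbon bound to a nitrogen on an aromatic ring and nothing else in the structure differs.

The expectation for this assay is a small step toward lower numbers, within the scatter, starting from compound 3 at 32 mL.min-1.g-1 and judged from the structural change alone. The estimated step is a 1.8-fold lower number from compound 3 to compound 4 (0.25 log units; within the scatter) and a report as a bare limit remains possible. In this assay compound 4 is expected at 18 mL.min-1.g-1 with a range from 11 mL.min-1.g-1 to 32 mL.min-1.g-1 as its estimate.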

Compound 4, intrinsic clearance in microsomes: < 14 mL.min-1.g-1
Compound 4 was reported as a limit; the forecaster's own chance of this, stated with the estimate: 30%; middle value at least 1.2-fold (0.10 log units) from the limit.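

In this assay compound 4 gives < 14 mL.min-1.g-1 as its reading, which is a limit of the assay and not a number. Among these compounds, this supplies the first comparison between compounds that differ in one place only, an at least 2.2-fold lower number from compound 3 to compound 4 (0.35 log units; beyond the scatter), so that on a saturated chain carbon bound to a nitrogen on an aromatic ring, pyridin-4-yl in place of 2-fluorophenyl goes with slower removal by a margin beyond the scatter, something the earlier compounds could not show. The full size of this step stays unknown, since it is bounded on one side only: the limit of < 14 mL.min-1.g-1 in this assay, at which 2 of the 4 values shown sit.

The compounds shown leave open whether the step belongs to the ring nitrogen that pyridin-4-yl brings in or to the loss of the fluorine that 2-fluorophenyl carries, and whether the same change would hold on the cores of compound 1 and compound 2. They also leave open how other groups would read at this place on the shared core, such as pyridin-3-yl, a morpholine or a longer chain.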